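Morpholin-4-yl to pyrrolidin-1-yl on the thiocarbonyl carbon

The source may hold more compounds than are shown below. What is called first, only, known or untested is meant among the compounds shown, and "the series" means these compounds.

Three compounds have been measured in a functional assay on A-375 cells (Homo sapiens) for cytotoxicity, read by MTT assay, with a stated time of 72 h, tested at 3 uM; a higher number here means more inhibition of growth at the concentration tested, a lower number less inhibition of growth:

compound 1, `N/C(=N\NC(=S)N1CCOCC1)c1ccccn1`, gives 19.3%
compound 2, `Cc1cccc(/C(N)=N/NC(=S)N2CCOCC2)n1`, gives 34.7%
compound 3, `Cc1cccc(/C(N)=N/NC(=S)N2CCCCCC2)n1`, gives 64.5%

Compound 2 stands second highest of the three numbers in this assay. Its nearest neighbour is compound 1, and the step of a number 15.4 percentage points higher from compound 1 to compound 2 (beyond the scatter). Among the compounds with values here, compound 3 lies furthest away with a higher number, and it differs from compound 2 in the ring on the thiocarbonyl carbon; no step is tabulated for that pair, so only the two values themselves speak.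

Compound 4, `Cc1cccc(/C(N)=N/NC(=S)N2CCCC2)n1`, differs from compound 2 by pyrrolidin-1-yl in place of morpholin-4-yl on a thiocarbonyl carbon. Within the data shown here, the one measured step, from compound 1 to compound 2, concerns the methyl on the aromatic carbon and not the ring on the thiocarbonyl carbon, so it does not bear directly on this change. The values of compound 2 and compound 3 show that exchanging the ring at that position can move the number beyond the scatter, upward in that instance. Compound 4 is therefore expected to land above compound 2, with the step of a number 12.3 percentage points higher from compound 2 to compound 4 (beyond the scatter) being the estimate. The estimated value for compound 4 is 47%, within a range from 30% to 65%.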

Compound 4, percent growth inhibition at one concentration: 51.3%
Estimate against measurement, compound 4: 4.3 percentage points below; the range from low to high includes it.
By their numbers in this assay, from the lowest: compound 1; then compound 2; then compound 4; then compound 3.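

In this assay, pyrrolidin-1-yl in place of morpholin-4-yl on the thiocarbonyl carbon gives a number 16.6 percentage points higher from compound 2 to compound 4 (beyond the scatter), the first step listed for a change at this position, and it shows that a ring with one hetero atom in place of a ring with two can raise the number on this core. With compound 2 at 34.7%, compound 4 at 51.3% and compound 3 at 64.5%, both rings that replace morpholin-4-yl give higher numbers, so the change at this position is not confined to a single replacement ring, and the printed values also place compound 4 below compound 3. No measurement available here explains why the number rises with this exchange.

The compounds shown do not separate the change in ring size from the loss of the ring oxygen, a question that piperidin-1-yl, a six-membered ring with nitrogen as its only hetero atom, would bear on directly. They also leave open how an open-chain dimethylamino group or a 4-methylpiperazin-1-yl ring would behave on the thiocarbonyl carbon, and whether pyrrolidin-1-yl would have the same effect on the core of compound 1.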